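This account rests on a few compounds, and the source may have more. Where it says the series, first, only, none or still open, it means among the compounds named here.

For the measured compounds named here, in an assay for inhibition of Neuropeptide Y receptor type 5 (Mus musculus) (a lower number here means a stronger inhibitor, a higher number a weaker inhibitor), compound 3 `CCc1ccccc1C(=O)c1cnc(Nc2cccc(C#N)c2)s1` gives 2.8 nM, the lowest of the three numbers measured so far: compound 1 `N#Cc1cccc(Nc2ncc(C(=O)c3ccccc3F)s2)c1` gives 19 nM, and compound 2 `O=C(c1cnc(Nc2cccc(C(F)(F)F)c2)s1)c1ccccc1C(F)(F)F` gives 138 nM. Compound 4 `N#Cc1cccc(Nc2ncc(C(=O)c3ccccc3C(F)(F)F)s2)c1` differs from compound 3 by trifluoromethyl in place of ethyl on an aromatic carbon. Going by the values given here, the single measured step that bears on this is a 6.8-fold lower number from compound 1 to compound 3 (0.83 log units; beyond the scatter), where ethyl took the place of fluoro on an aromatic carbon; the new change takes that ethyl away again and puts trifluoromethyl in its place. Among the compounds with values here, compound 2 also carries trifluoromethyl, but it differs from compound 4 in more than one place, so its value shows only that a high number is possible. Compound 4 is therefore expected to give a higher number, by a 5.4-fold higher number from compound 3 to compound 4 (0.73 log units; beyond the scatter). For compound 4 the estimate is 15 nM, expected to fall between 4 nM and 60 nM.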

Compound 4, half-maximal inhibitory concentration: 20 nM
For compound 4 the middle estimate is 1.3-fold (0.12 log units) below the measured one; measured number inside the range.
By their numbers in this assay, from the lowest: compound 3; then compounds 1 and 4 (each within the scatter of the next); then compound 2.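

In this assay, trifluoromethyl in place of ethyl at this position gives a 7.1-fold higher number from compound 3 to compound 4 (0.85 log units; beyond the scatter) and so does not keep the lower number seen with ethyl. Set against fluoro, trifluoromethyl shows a 1.1-fold higher number from compound 1 to compound 4 (0.02 log units; within the scatter) and the two cannot be told apart, so among these three groups only ethyl stands out. With trifluoromethyl held at this position, the second place also counts, as cyano in place of trifluoromethyl gives a 6.9-fold lower number from compound 2 to compound 4 (0.84 log units; beyond the scatter) in this series.

Nothing given here accounts for these differences. As far as these compounds go, whether a longer chain such as propyl, or an amine, would go lower than ethyl at this position remains open.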